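Extending the thioether arm of compound 3

A few compounds are considered here, and "the series" means these few. Any claim that something is new, unique, unknown or untested is made for them only; others in the source may bear on it.

Compound 3 `CCCc1nnc(SCc2ccccc2)n1N1C(=O)c2ccccc2C1=O` carries a benzyl group on the sulfur of the shared core. In a functional assay on A549 cells (Homo sapiens) for cytotoxicity, read by MTT assay, with a stated time of 48 h (a higher number here means a weaker inhibitor, a lower number a stronger inhibitor), compound 3 gives > 200000 nM, which is a limit of the assay rather than a number. Compound 1 `Cc1ccc(C(=O)CSc2nnc(C)n2N2C(=O)c3ccccc3C2=O)cc1` gives > 200000 nM, also a limit. Compound 2 `CCc1nnc(SCC(=O)c2ccc(C)cc2)n1N1C(=O)c2ccccc2C1=O` gives > 200000 nM, again a limit. The step that the two limits leave unreadable from compound 1 to compound 2 therefore cannot be read, and the limit of > 200000 nM in this assay, at which 3 of the 3 values shown sit, is all the evidence there is. Compound 4 `CCCc1nnc(SCC(=O)c2ccc(C)cc2)n1N1C(=O)c2ccccc2C1=O` differs from compound 3 by (4-methylphenyl)carbonyl in place of phenyl on a saturated chain carbon bound to a sulfur. Compounds 1 and 2 already carry that same arm and sit at the limit, so no readable step bears on this change. The step of a number no higher from compound 3 to compound 4 (the limit leaves the size open) is expected to show no readable size. The estimate for compound 4 is 200000 nM, with a range from 100000 nM to 500000 nM, most likely reported again only as a limit.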

Compound 4, half-maximal inhibitory concentration: > 200000 nM
Compound 4: only a limit was reported (the forecaster's own chance of this, stated with the estimate: 85%); the middle value lies on the limit itself.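

Compound 4 sits at the limit of the assay, like compound 1, compound 2 and compound 3, so no step among them can be read: the limit of > 200000 nM in this assay, at which 4 of the 4 values shown sit.

The compounds shown leave open whether any change to the shared core gives a readable value in this assay.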